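Swapping a styryl arm for a nitrophenyl on a shared core

The source may hold more compounds than are shown below. What is called first, only, known or untested is meant among the compounds shown, and "the series" means these compounds.

Three sulfonamide-bearing hydrazones have been measured in a functional assay on HepG2 cells (Homo sapiens) for cytotoxicity, read by sulforhodamine B assay, with a stated time of 48 h; a lower number here means a stronger inhibitor, a higher number a weaker inhibitor. Compound 1 `C/C(=N\NC(=O)/C(C#N)=C/N(C)C)c1ccc(NS(=O)(=O)c2ccc(Cl)cc2)cc1` gives 19400 nM, and compound 2 `C/C(=N\NC(=O)C(C#N)C(=S)S)c1ccc(NS(=O)(=O)c2ccc(Cl)cc2)cc1` gives 17500 nM; the step of a 1.1-fold lower number from compound 1 to compound 2 (0.04 log units; within the scatter). Compound 3 `CCOC(=O)c1c(/C=C/c2ccccc2)c(C#N)c(=O)n(/N=C(\C)c2ccc(NS(=O)(=O)c3ccc(Cl)cc3)cc2)c1N` gives 10700 nM, the lowest of the three numbers, though its gaps to compound 2 and compound 1 both sit within the scatter. Compound 4 `CCOC(=O)c1c(-c2cccc([N+](=O)[O-])c2)c(C#N)c(=O)n(/N=C(\C)c2ccc(NS(=O)(=O)c3ccc(Cl)cc3)cc2)c1N` differs from compound 3 by 3-nitrophenyl in place of 2-phenylethenyl on an aromatic carbon. Within the data shown here, no measured step touches this position; the only recorded step, on a carbonyl carbon, was flat. He therefore expects no step beyond the scatter in this assay, with a 1.1-fold lower number from compound 3 to compound 4 (0.03 log units; within the scatter). For compound 4 he estimates 10000 nM, in a range from 4000 nM to 25000 nM.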

Compound 4, half-maximal inhibitory concentration: 29700 nM
Compound 4: the middle estimate sits 3.0-fold (0.47 log units) below what was measured; measured number outside the range, above it.
By their numbers in this assay, from the lowest: compounds 3, 2, 1 and 4 (each within the scatter of the next, the first and the last beyond it).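

In this assay, among these compounds, the exchange of 2-phenylethenyl for 3-nitrophenyl gives a 2.8-fold higher number from compound 3 to compound 4 (0.44 log units; beyond the scatter) and is the first step in this set to pass beyond the scatter. The aromatic carbon opposite the ring nitrogen therefore responds to a change of group, unlike the flat step on the carbonyl carbon. No measurement offered here accounts for the higher number.

From the compounds shown here alone, with one step at this position, it remains open whether a plain phenyl, a 3-aminophenyl or a methyl would stay near compound 3 or move towards compound 4.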